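Swapping a thiophene for a methoxyphenyl: what happens to cytotoxicity

This account rests on a few compounds, and the source may have more. Where it says the series, first, only, none or still open, it means among the compounds named here.

Measured so far:
- compound 1, `c1ccc(CCSCc2cnc3ccc(-c4ccccc4)cn23)cc1`: 4 ug/mL
- compound 2, `Cc1cc(-c2ccsc2)c2ncc(CSCCc3ccccc3)n2c1`: 100 ug/mL
- compound 3, `COc1cccc(-c2cc(C)c3ncc(CSCCc4ccccc4)n3c2)c1`: 20 ug/mL

These three compounds were tested in an ADME assay on HEL cells (Homo sapiens) for cytotoxicity, with a stated time of 3 days; on this read-out higher numbers stand for lower toxicity in this test and lower numbers for higher toxicity in this test. Compound 2 stands at the top of the three numbers, with the least toxicity in this set. Its nearest neighbour is compound 3, whose number in this assay is lower, a gap beyond the usual scatter, and the furthest is compound 1, whose number is lower still, also beyond the scatter.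

The next compound, compound 4, has the structure `COc1ccc(-c2cc(C)cn3c(CSCCc4ccccc4)cnc23)cc1`. Compared with compound 2 it carries one change: 4-methoxyphenyl in place of thiophen-3-yl on an aromatic carbon. The methyl group and the rest of the shared core stay as they are.

Within the data shown here, no step between two measured compounds matches this change exactly, so the expectation has to lean on what the set shows. Compound 3, which also carries a methoxyphenyl on the same core, gives 20 ug/mL, well below compound 2. On that basis a step toward lower numbers in this assay, that is toward higher toxicity, is expected for compound 4, of a size beyond the scatter, as a 3.3-fold lower number from compound 2 to compound 4 (0.52 log units; beyond the scatter). The number expected for compound 4 is 30 ug/mL, within a range from 10 ug/mL to 100 ug/mL.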

Compound 4, minimum cytotoxic concentration: 20 ug/mL
Beside the measured number, compound 4's estimate is 1.5-fold (0.18 log units) above it, and the stated range covers the measured number.
By their numbers in this assay, from the lowest: compound 1; then compounds 3 and 4 (each within the scatter of the next); then compound 2.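

In this assay, among these compounds, replacing thiophen-3-yl with 4-methoxyphenyl on this aromatic carbon gives a 5.0-fold lower number from compound 2 to compound 4 (0.70 log units; beyond the scatter), the first direct reading of a single change in this set. It shows that the number responds to the group held at this position while the methyl group and the rest of the shared core stay fixed, and that this swap moves toward higher toxicity in this test. Among the compounds shown here, compound 3 also carries a methoxyphenyl, but it differs from compound 4 in more than one place, so only this step isolates the change, and nothing measured here explains why the number moves.

One step cannot show whether the shift comes from leaving the five-membered ring with its sulfur, from entering a six-membered ring of carbon only, or from the methoxy group itself, and compound 1 cannot settle this since it differs from compound 4 in more than one place. On these data alone, it also remains open whether a pyridine ring, or a phenyl ring bearing an amine or a carboxylic acid, at this position would stay nearer to compound 2 at 100 ug/mL or fall toward compound 4 at 20 ug/mL.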